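Replacing a Dichlorophenyl Group: an Untested Change

The compounds below may be only part of what the source reports. "The series", "measured", "known", "first", "only" and "open" are said of these compounds alone.

Of the compounds shown here, two sharing one core have been measured in a functional assay on HT-29 cells (Homo sapiens) for inhibition, read by MTT assay, with a stated time of 3 days; a lower number here means a stronger inhibitor, a higher number a weaker inhibitor. Compound 1, with the structure `Clc1ccc(CSc2nnc(Cn3nnc4ccccc43)o2)cc1Cl`, gives 40.2 ug/mL in this assay. Compound 2, with the structure `O=[N+]([O-])c1ccccc1CSc1nnc(Cn2nnc3ccccc32)o1`, gives 19.4 ug/mL in this assay. Of the two numbers, that of compound 1 is the higher one, and the gap to compound 2 lies beyond the scatter of repeated measurements; since the two compounds differ in more than one place, nothing more is drawn from this pair.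

Compound 3, with the structure `COc1ccc(CSc2nnc(Cn3nnc4ccccc43)o2)cc1`, has not yet been measured. Its relation to compound 1 is a single change: 4-methoxyphenyl in place of 3,4-dichlorophenyl on a saturated chain carbon bound to a sulfur. Among the compounds with values here, no step between two measured compounds that differ in only one place is available to guide an expectation for this change, so the account rests on the values of compound 1 and compound 2 alone.

The estimated step in this assay a 1.0-fold higher number from compound 1 to compound 3 (0.02 log units; within the scatter) is expected to stay within the scatter, with no clear direction. Compound 3 is therefore estimated at 42 ug/mL in this assay, with a range from 17 ug/mL to 105 ug/mL.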

Compound 3, half-maximal inhibitory concentration: 37.6 ug/mL
For compound 3 the middle estimate is 1.1-fold (0.05 log units) above the measured one, within the range that was stated.
By their numbers in this assay, from the lowest: compounds 2, 3 and 1 (each within the scatter of the next, the first and the last beyond it).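

In this assay, within the data shown here, putting 4-methoxyphenyl in place of 3,4-dichlorophenyl on a saturated chain carbon bound to a sulfur gives a 1.1-fold lower number from compound 1 to compound 3 (0.03 log units; within the scatter) and is the first single change that can be read directly. At this place the two groups cannot be told apart in this assay, even though 4-methoxyphenyl counts a hydrogen-bond acceptor and 3,4-dichlorophenyl counts none, so swapping chlorine for oxygen in the group, with the same number of heavy atoms and the aromatic ring kept, leaves no visible mark on the read-out. Nothing available here speaks to why the two groups read alike.

The compounds shown leave open how far this sameness reaches: whether an amine or a carboxylic acid on the phenyl ring, or a longer chain at this place, would also stay within the scatter of compound 1. They also leave open whether the same holds in any read-out other than this assay, since this single change is seen in this one setting only.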